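Compound 3 to compound 4: changing the carbonyl substituent

This account rests on a few compounds, and the source may have more. Where it says the series, first, only, none or still open, it means among the compounds named here.

- compound 1 `COc1ccc(S(=O)(=O)Nc2ccc(-c3nc4cc(NS(=O)(=O)c5ccc(OC)cc5)ccc4o3)cc2)cc1`: 57000 nM
- compound 2 `O=S(=O)(Nc1ccc(-c2nc3cc(NS(=O)(=O)c4ccc(Cl)s4)ccc3o2)cc1)c1ccc(Cl)c(C(F)(F)F)c1`: 63000 nM
- compound 3 `COc1ccc(S(=O)(=O)Nc2ccc3oc(-c4ccc(NC(=O)c5ccc(Cl)s5)cc4)nc3c2)cc1`: > 100000 nM

These values come from an ADME assay on FHC cells (Homo sapiens) for cytotoxicity, read by resazurin assay, with a stated time of 48 h; on this read-out higher numbers stand for lower toxicity in this test and lower numbers for higher toxicity in this test. The entry for compound 3 is a limit of the assay and not a number.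

The next change leads to compound 4 `COc1ccc(S(=O)(=O)Nc2ccc3oc(-c4ccc(NC(=O)C5CCN(C(C)=O)CC5)cc4)nc3c2)cc1`: 1-acetylpiperidin-4-yl in place of 5-chlorothiophen-2-yl on a carbonyl carbon. In words, 1-acetylpiperidin-4-yl takes the place of 5-chlorothiophen-2-yl on a carbonyl carbon.

Within the data shown here, the only measured step bearing on this is an at least 1.7-fold higher number from compound 1 to compound 3 (0.24 log units; that floor lies within the scatter). Among the measured compounds shown here, it involves the same (5-chlorothiophen-2-yl)carbonyl group, but no measured step exchanges it for another carbonyl group. No step beyond the scatter is therefore expected in this assay.

The expected step is a number no higher from compound 3 to compound 4 (the limit leaves the size open). Compound 4 is estimated at 100000 nM, within an expected range of 50000 nM to 200000 nM.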

Compound 4, half-maximal cytotoxic concentration: > 100000 nM
Compound 4: a limit, no number; the forecaster's own chance of this, stated with the estimate: 65%; the middle value sits exactly at the limit.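

In this assay compound 4 gives > 100000 nM, which is a limit of the assay and not a number. The 1-acetylpiperidin-4-yl group on this carbonyl carbon thus reaches the same limit as the 5-chlorothiophen-2-yl group of compound 3, so a second, non-aromatic ring is now tolerated here, and the step between these two compounds cannot be read. The (1-acetylpiperidin-4-yl)carbonyl group in place of (4-methoxyphenyl)sulfonyl gives an at least 1.7-fold higher number from compound 1 to compound 4 (0.24 log units; that floor lies within the scatter), and the read-out is crowding at its limit: the limit of > 100000 nM in this assay, at which 2 of the 4 values shown sit.

As far as these compounds go, whether a carbonyl substituent carrying a free amine or a carboxylic acid would give a number under the limit remains open.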